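Cyclohexyl in place of 1H-imidazol-4-yl: working notes

A few compounds are considered here, and "the series" means these few. Any claim that something is new, unique, unknown or untested is made for them only; others in the source may bear on it.

Values so far in a functional assay on NCI-H460 cells (Homo sapiens) for cytotoxicity, read by MTT assay, with a stated time of 72 h (on this read-out lower numbers stand for stronger inhibition and higher numbers for weaker inhibition), are these:
- compound 1 `CC(C)c1[nH]cnc1/C=c1\[nH]c(=O)/c(=C/c2cccc(Oc3ccc(F)cc3)c2)[nH]c1=O` gives 8.8 nM as its value
- compound 2 `O=c1[nH]/c(=C\c2c[nH]cn2)c(=O)[nH]/c1=C\c1cccc(Oc2ccc(F)cc2)c1` gives 479 nM as its value

Among the compounds with values here, of the two, compound 2 holds the higher number, and the only measured step runs a 54-fold higher number from compound 1 to compound 2 (1.74 log units; beyond the scatter) and lies within the group that leaves next. Compound 3 `O=c1[nH]/c(=C\C2CCCCC2)c(=O)[nH]/c1=C\c1cccc(Oc2ccc(F)cc2)c1` carries the change cyclohexyl in place of 1H-imidazol-4-yl on a double-bonded chain carbon bound to an aromatic carbon with cyclohexyl in place of 1H-imidazol-4-yl on a double-bonded chain carbon bound to an aromatic carbon. Within the data shown here, no measured step replaces that whole group, so the evidence is indirect. The large step to compound 2 shows only that this assay can respond strongly to a change in that group. A further rise of moderate size is therefore expected, though the direction rests on little. The expected step runs a 3.1-fold higher number from compound 2 to compound 3 (0.50 log units; beyond the scatter) and would probably lie beyond the scatter. The estimate for compound 3 is 1500 nM as the expected value, with an estimated range from 250 nM to 9000 nM in this read-out.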

Compound 3, half-maximal inhibitory concentration: > 1000 nM
Compound 3 was reported as a limit; the forecaster's own chance of this, stated with the estimate: 10%; the middle value does not contradict the limit.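

In this assay compound 3 is reported only as a limit of the assay, not as a number: the limit of > 1000 nM in this assay, at which 1 of the 3 values shown sits.

Until now, the ring at this position was kept and only its isopropyl group changed; here the ring itself is replaced, and cyclohexyl in place of 1H-imidazol-4-yl gives an at least 2.0-fold higher number from compound 2 to compound 3 (0.31 log units; beyond the scatter), so this non-aromatic carbon ring, with 0 hydrogen-bond donors and 0 hydrogen-bond acceptors, does not match compound 2. From the compounds shown here alone, the wider change from the isopropyl-bearing ring gives an at least 110-fold higher number from compound 1 to compound 3 (2.05 log units; beyond the scatter), and both steps are lower bounds whose true size remains unknown.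

The compounds shown do not separate the loss of ring aromaticity from the loss of the ring nitrogens. Phenyl or pyridin-2-yl on the double-bonded chain carbon would bear on this, and whether an isopropyl group on such a ring would bring a gain like that seen in compound 1 remains open.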